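Series notes: anilino-substituted core, cytotoxicity on colon cells

The source may report more compounds than this note shows. Statements on the series, on what has been measured and on what is new or still open speak of the compounds shown alone.

Measured compounds:
compound 1, `Fc1cccc(-c2nc(Nc3ccc(Cl)cc3)c3cc(F)ccc3n2)c1`, 40300 nM
compound 2, `Fc1cccc(-c2nc(Nc3ccc(Br)cc3)c3cc(F)ccc3n2)c1`, > 50000 nM
compound 3, `Fc1cccc(-c2nc(Nc3ccccc3Br)c3cc(F)ccc3n2)c1`, > 50000 nM

The three measured compounds share one core and differ only in the aryl group on the ring nitrogen. In a functional assay on HT29-AK cells (Homo sapiens) for cytotoxicity, read by MTT assay, with a stated time of 48 h (a higher number here means a weaker inhibitor, a lower number a stronger inhibitor), compound 1 gives 40300 nM. For compound 2 the result is a limit of the assay, > 50000 nM. For compound 3 the result is likewise a limit, > 50000 nM, and compound 3 therefore stands at the limit of > 50000 nM in this assay, at which 2 of the 3 values shown sit; no number is known for it. The two steps that can be read, an at least 1.2-fold higher number from compound 1 to compound 2 (0.09 log units; that floor lies within the scatter) and an at least 1.2-fold higher number from compound 1 to compound 3 (0.09 log units; that floor lies within the scatter), are both at least small increases whose floor lies within the scatter, while a step that the two limits leave unreadable from compound 2 to compound 3 cannot be sized.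

Compound 4, `Oc1cccc(Nc2nc(-c3cccc(F)c3)nc3ccc(F)cc23)c1`, is the next member. The change from compound 3 is 3-hydroxyphenyl in place of 2-bromophenyl on a nitrogen on an aromatic ring. For the measured compounds named here, none of the measured steps moves the hydroxyl or changes an aryl substituent of this kind, so no step bears directly on it; what the series shows is that every aryl variant so far sits at or near the limit in this assay. The expectation for compound 4 is therefore a value of the same order, with an at least 1.4-fold lower number from compound 3 to compound 4 (0.15 log units; that floor lies within the scatter) carrying no clear direction beyond the scatter. Compound 4 is estimated at 35000 nM, within 10000 nM to 50000 nM.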

Compound 4, half-maximal inhibitory concentration: > 50000 nM
Compound 4: only a limit was reported; the forecaster's own chance of this, stated with the estimate: 50%; at least 1.4-fold (0.15 log units) between middle value and limit.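

In this assay, compound 4 gives only a limit of the assay, > 50000 nM. For the compounds shown here, the one readable step is an at least 1.2-fold higher number from compound 1 to compound 4 (0.09 log units; that floor lies within the scatter), while the steps from compound 2 and compound 3 to compound 4 cannot be read, as limits stand at both ends. Thus 3-hydroxyphenyl, the only aryl group shown with a hydrogen-bond donor, gives no measurable value on the ring nitrogen and joins the 4-bromophenyl and 2-bromophenyl compounds at the same limit: the limit of > 50000 nM in this assay, at which 3 of the 4 values shown sit.

The limits leave the order among compound 2, compound 3 and compound 4 unknown, and compound 1 cannot be set apart from them beyond the scatter. From the compounds shown here alone, it remains open whether an amine or a carboxylic acid on the aryl group in place of the hydroxyl would give a value that can be read in this assay.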